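The compounds below may be only part of what the source reports. "The series", "measured", "known", "first", "only" and "open" are said of these compounds alone.

Measured so far:
compound 1 `O=C(Nc1nc2ccccc2s1)c1cn(-c2ccccc2)nc1-c1ccccc1` — 8960 nM in a functional assay on U-87MG ATCC cells for cytotoxicity against U-87 MG (Homo sapiens), read by MTT assay, with a stated time of 72 h; a higher number here means a weaker inhibitor, a lower number a stronger inhibitor
compound 2 `O=C(Nc1nc2ccc(Cl)cc2s1)c1cn(-c2ccccc2)nc1-c1ccccc1` — 4980 nM in this assay

For the measured compounds named here, only two numbers exist, and a 1.8-fold lower number from compound 1 to compound 2 (0.26 log units; within the scatter), so compound 2 stands together with compound 1 inside the scatter rather than apart from it. Compound 3 `COc1ccc(-c2nn(-c3ccccc3)cc2C(=O)Nc2nc3ccc(Cl)cc3s2)cc1` differs from compound 2 by methoxy in place of hydrogen on an aromatic carbon. Going by the values given here, no measured step touches this position: the single step seen, chloro in place of hydrogen, sits elsewhere and was itself within the scatter. Nothing beyond the scatter is therefore expected in this assay. Compound 3 is estimated at 4500 nM (1500 nM to 13000 nM), an expected 1.1-fold lower number from compound 2 to compound 3 (0.04 log units; within the scatter).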

Compound 3, half-maximal inhibitory concentration: 8710 nM
Compound 3: the middle estimate sits 1.9-fold (0.29 log units) below what was measured, and the stated range covers the measured number.
By their numbers in this assay, from the lowest: compounds 2, 3 and 1 (each within the scatter of the next).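

Phenyl to 4-methoxyphenyl gives a 1.7-fold higher number from compound 2 to compound 3 (0.24 log units; within the scatter) in this assay and is the first change read at this position. For the compounds shown here, a methoxy on this aromatic carbon, para to a large group, therefore gives no step that separates from the scatter. No available evidence bears on the reason for this result.

From the compounds shown here alone, whether an amine or a carboxylic acid at this position would separate from compound 2 stays open. Also open, going by these compounds, is whether methoxy would read the same on compound 1, which lacks the chloro.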